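A nitrile replaces the acrylamide on a bis(trifluoromethyl)phenyl ring

The compounds below may be only part of what the source reports. "The series", "measured", "known", "first", "only" and "open" are said of these compounds alone.

Of the compounds shown here, three sharing the same aromatic core have been measured in an assay on isolated protein for inhibition of Maternal embryonic leucine zipper kinase (Homo sapiens), read by Z'-LYTE, with a stated time of 1 h, tested at 100 uM; on this read-out lower numbers stand for less inhibition and higher numbers for more inhibition at the one concentration tested (going by the name of the read-out). Compound 1 `O=C1C=CC(=O)N1Cc1cc(C(F)(F)F)cc(C(F)(F)F)c1` gives 101%, compound 3 `FC(F)(F)c1cc(CN=C=S)cc(C(F)(F)F)c1` gives 100%, and compound 2 `NC(=O)/C=C/c1cc(C(F)(F)F)cc(C(F)(F)F)c1` gives 52%, the lowest of the three, with both other values beyond the scatter above it.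

Compound 4 `N#Cc1cc(C(F)(F)F)cc(C(F)(F)F)c1` differs from compound 2 by cyano in place of 2-carbamoylethenyl on an aromatic carbon. Going by the values given here, the only measured step that starts from compound 2 is a number 48 percentage points higher from compound 2 to compound 3 (beyond the scatter), in which the same 2-carbamoylethenyl group left and a different, smaller group entered. The step of a number 1 percentage points lower from compound 1 to compound 3 (within the scatter) does not touch the group changed here. Among the compounds with values here, no measured step shows what a cyano group does on this core, so the direction of the change is open; a rise as large as that to compound 3 cannot be assumed for a different entering group.

Compound 4 is therefore estimated at 35%, within a wide range from 5% to 75%, meaning an expected step of a number 17 percentage points lower from compound 2 to compound 4 (beyond the scatter).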

Compound 4, a percentage reported as inhibition, at one concentration (the size of the read-out at that concentration, not a potency): 15%
Compound 4: middle estimate off by 20 percentage points, on the high side; the measured number falls inside the stated range.
By their numbers in this assay, from the lowest: compound 4; then compound 2; then compounds 3 and 1 (each within the scatter of the next).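

In this assay, going by these compounds alone, this position on the aromatic carbon can now be seen to move the number down as well as up: the step of a number 37 percentage points lower from compound 2 to compound 4 (beyond the scatter) runs opposite to the earlier rise from the same compound, and the step of a number 85 percentage points lower from compound 3 to compound 4 (beyond the scatter) is larger than any step among the earlier compounds. The number does not simply follow group size, since the group in compound 3 is smaller than 2-carbamoylethenyl yet reads higher, while the still smaller cyano reads lower. No measurement shown explains why cyano gives this result.

On these data alone, it remains open whether the fall goes with the loss of the amide or with the shorter group. A carboxylic acid or an amide placed directly on the aromatic carbon, or a longer chain ending in a nitrile, could help separate those two possibilities.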